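Compound 1 to compound 3: methyl to benzyl

The source may report more compounds than this note shows. Statements on the series, on what has been measured and on what is new or still open speak of the compounds shown alone.

In a functional assay on HepG2 cells (Homo sapiens) for inhibition, read by MTT assay, with a stated time of 72 h, tested at 30 uM (a higher number here means more inhibition of growth at the concentration tested, a lower number less inhibition of growth), compound 1 (`C=CCc1cc(O)c(O)c(CN2CCC(C)CC2)c1`) gives 57.6% as the higher of the two numbers in hand. In this assay compound 2 (`C=CCc1ccc(OCc2cn(-c3cc(OC)c(OC)c(OC)c3)nn2)c(O)c1`) reaches only 1.2% and so lies below compound 1 by a gap beyond the usual scatter. The two structures differ in more than one place, so this gap cannot be assigned to any single group.

Compound 3 (`C=CCc1cc(O)c(O)c(CN2CCC(Cc3ccccc3)CC2)c1`) keeps the core of compound 1 and differs from it in one place (phenyl in place of hydrogen on a saturated chain carbon bound to a saturated ring carbon): phenyl in place of hydrogen on a saturated chain carbon bound to a saturated ring carbon. The same difference reads as methyl to benzyl. Among the compounds with values here, no measured pair isolates this change, so the expectation rests on compound 1 at 57.6% and on the change itself. The estimated step of a number 4.4 percentage points higher from compound 1 to compound 3 (within the scatter) is a small rise in this assay and is not expected to go beyond the scatter. For compound 3 the estimated value is 62% within an expected range from 37% to 90% for repeat measurements.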

Compound 3, percent growth inhibition at one concentration: 70.2%
Estimate against measurement, compound 3: 8.2 percentage points below, within the range that was stated.
By their numbers in this assay, from the lowest: compound 2; then compound 1; then compound 3.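

In this assay the change from methyl to benzyl gives the series its first comparison in one place: a number 12.6 percentage points higher from compound 1 to compound 3 (beyond the scatter), a modest step but one beyond the scatter. This shows that phenyl in place of hydrogen, on a saturated chain carbon bound to a saturated ring carbon, is tolerated at this position, and that here it goes with more growth inhibition at the concentration tested. The rise can be tied to this single change, which the gap between the two earlier compounds, differing in more than one place, did not allow, but nothing on hand gives a reason for it.

Open, from the compounds shown here alone, is whether the aromatic ring itself is needed at this place: a cyclohexylmethyl group, a phenethyl chain or a benzyl group carrying a methoxy substituent would each bear on that question. Going by these compounds, with a read-out at one concentration, the full concentration response of compound 3 also stays open.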